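The compounds below may be only part of what the source reports. "The series", "measured", "known", "first", "only" and "open" are said of these compounds alone.

In a functional assay on A549 cells (Homo sapiens) for cytotoxicity, read by MTT assay, with a stated time of 72 h (a higher number here means a weaker inhibitor, a lower number a stronger inhibitor), three compounds sharing one core have been measured. Compound 1 (`COc1cccc(/C=C2\CCC/C(=C\c3cccc(O)c3)C2=O)c1OC`) gives > 20000 nM, which is a limit of the assay and not a number. Within the data shown here, compound 2 (`COc1ccc(/C=C2\CCC/C(=C\c3cccc(Cl)c3)C2=O)cc1OC`) gives 11000 nM, the only true number of the three. Compound 3 (`COc1ccc(/C=C2\CCC/C(=C\c3ccccc3Br)C2=O)cc1OC`) gives > 20000 nM, again a limit and not a number. Compound 3 therefore rests on (the limit of > 20000 nM in this assay, at which 2 of the 3 values shown sit).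

Compound 4 (`COc1ccc(/C=C2\CCC/C(=C\c3cccc(O)c3)C2=O)cc1OC`) differs from compound 3 in one place: 3-hydroxyphenyl in place of 2-bromophenyl on a double-bonded chain carbon bound to a double-bonded ring carbon. It carries 3-hydroxyphenyl in place of 2-bromophenyl on a double-bonded chain carbon bound to a double-bonded ring carbon. Among the measured compounds shown here, the only measured step at this place is an at least 1.8-fold higher number from compound 2 to compound 3 (0.25 log units; that floor lies within the scatter), and it does not clear the usual scatter. Compound 1 also carries 3-hydroxyphenyl, and its > 20000 nM is a limit, so it offers little hope of a large gain. Only a small step toward a lower number is therefore expected in this assay, perhaps none beyond the scatter. For compound 4 the expected value is 15000 nM, with an estimated range of 6000 nM to 30000 nM. The estimated change is an at least 1.3-fold lower number from compound 3 to compound 4 (0.12 log units; that floor lies within the scatter).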

Compound 4, half-maximal inhibitory concentration: 4300 nM
Compound 4: the middle estimate sits 3.5-fold (0.54 log units) above what was measured; the measured number lies below the stated range.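

In this assay, this place on a double-bonded chain carbon bound to a double-bonded ring carbon now shows changes that clear the scatter: 3-hydroxyphenyl in place of 2-bromophenyl gives an at least 4.6-fold lower number from compound 3 to compound 4 (0.66 log units; beyond the scatter), and hydroxy in place of chloro gives a 2.6-fold lower number from compound 2 to compound 4 (0.41 log units; beyond the scatter). The first of these steps is only a floor, because compound 3 rests on a limit: the limit of > 20000 nM in this assay, at which 2 of the 4 values shown sit. Compound 1, which also carries 3-hydroxyphenyl, gives > 20000 nM, a limit and not a number, so it goes against any reading that this group alone brings the lower number.

As far as these compounds go, whether an amine or a carboxylic acid in place of the hydroxy would lower the number further remains open. The compounds shown also do not tell whether the hydroxy gain would hold on a different arrangement of the methoxy groups.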